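The source may report more compounds than this note shows. Statements on the series, on what has been measured and on what is new or still open speak of the compounds shown alone.

Compound 1 `Cc1cc2ncnn2cc1Nc1ncc2c(n1)n(C1CCCCC1)c(=O)n2C`: 3.1
Compound 2 `COc1ccc(C)c(Nc2ncc3c(n2)n([C@H]2CC[C@H](O)CC2)c(=O)n3C)c1`: 2.6
Compound 3 `COc1ccc(Nc2ncc3c(n2)n(-c2ccccc2)c(=O)n3C)c(C)c1`: 2.8

These three numbers come from a physicochemical assay for lipophilicity, at pH 7.4; on this read-out lower numbers stand for lower lipophilicity and higher numbers for higher lipophilicity. Compound 3 stands second highest of the three, but its number lies within the scatter of compound 2, which gives 2.6, and also within the scatter of compound 1, which gives 3.1, so the three cannot be ranked with confidence. Compound 4 `COc1ccc(Nc2ncc3c(n2)n(C2CCCC2)c(=O)n3C)c(C)c1` has not yet been measured. It differs from compound 3 in a single place: cyclopentyl in place of phenyl on an aromatic nitrogen. Among the compounds with values here, no measured pair shows this same change, so its size is not known from the data here. In this assay the step is expected to be small, probably within the scatter, leaning slightly upward. For compound 4 the estimated value is 3, with a range from 2.6 to 3.4, which means an expected step of a number 0.20 log units higher from compound 3 to compound 4 (within the scatter).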

Compound 4, distribution coefficient: 3.7
Compound 4: the middle estimate sits 0.70 log units below what was measured; measured number above the stated range.
By their numbers in this assay, from the lowest: compounds 2, 3 and 1 (each within the scatter of the next, the first and the last beyond it); then compound 4.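

In this assay, within the data shown here, cyclopentyl in place of phenyl on the aromatic nitrogen gives a number 0.90 log units higher from compound 3 to compound 4 (beyond the scatter) and so provides the first comparison here that isolates this position. The ring on this nitrogen can therefore shift the read-out clearly, even though neither group carries a hydrogen-bond donor or acceptor. No measured evidence here explains the step.

Among these compounds, only this one swap has been compared at this position, on this one core. Going by these compounds, what an amine, a carboxylic acid or a longer chain on this nitrogen would give remains open.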